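Acetylation of the benzylic amine in the bromophenyl coumarin ester series

A few compounds are considered here, and "the series" means these few. Any claim that something is new, unique, unknown or untested is made for them only; others in the source may bear on it.

The three measured compounds share one core and differ only in the group on the saturated chain carbon bound to an aromatic carbon. Compound 1 `CCCC(=O)OCc1ccc2oc(=O)c(C(=O)Oc3cccc(Br)c3)cc2c1` gives 88.6% in a functional assay on HT-1080 cells (Homo sapiens), read by transwell migration, with a stated time of 24 h, tested at 0.1 uM; a lower number here means a stronger effect, a higher number a weaker effect of the compound at the concentration tested. Compound 2 `CCCCCC(=O)OCc1ccc2oc(=O)c(C(=O)Oc3cccc(Br)c3)cc2c1` gives 94.3% in this assay, and a number 5.7 percentage points higher from compound 1 to compound 2 (within the scatter). Compound 3 `NCc1ccc2oc(=O)c(C(=O)Oc3cccc(Br)c3)cc2c1` gives 88.3% in this assay; its number is nominally the smallest of the three, yet a number 0.3 percentage points lower from compound 1 to compound 3 (within the scatter) and a number 6 percentage points lower from compound 2 to compound 3 (within the scatter), so the three compounds are not separated by this read-out.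

Compound 4 `CC(=O)NCc1ccc2oc(=O)c(C(=O)Oc3cccc(Br)c3)cc2c1` has not yet been measured in this assay. It differs from compound 3 by acetyl in place of hydrogen on an amine nitrogen. Among the compounds with values here, no measured step alters this nitrogen, so the closest precedent is the replacement of the whole ester by the amine in the steps from compound 1 and compound 2 to compound 3, both within the scatter. Exchanging an ester for an amine on this chain carbon left the read-out unchanged; a smaller change at the same position is therefore expected to do the same, with no step beyond the scatter.

The expected step is a number 1.7 percentage points higher from compound 3 to compound 4 (within the scatter). Compound 4 is estimated at 90%, between 79% and 100%.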

Compound 4, a percentage reported as activity, at one concentration (the size of the read-out at that concentration, not a potency): 34.4%
Estimate against measurement, compound 4: 55.6 percentage points above; the whole stated range lies above it.
By their numbers in this assay, from the lowest: compound 4; then compounds 3, 1 and 2 (each within the scatter of the next).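

In this assay, within the data shown here, the amine nitrogen on the saturated chain carbon proves to be a sensitive point: acetyl in place of hydrogen there gives a number 53.9 percentage points lower from compound 3 to compound 4 (beyond the scatter) and is the first change to move the read-out beyond the scatter. Acetamido also separates from both esters on this chain carbon, with a number 54.2 percentage points lower from compound 1 to compound 4 (beyond the scatter) and a number 59.9 percentage points lower from compound 2 to compound 4 (beyond the scatter), so the carbonyl carried by the (propylcarbonyl)oxy and (pentylcarbonyl)oxy groups does not by itself reproduce the result, and the earlier silence of this position held only for the amine and those two esters. Nothing available explains why the amide differs from the amine and the esters.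

The compounds shown leave open whether the step belongs to acetyl itself or to acylation of this nitrogen more generally, which a propanoyl, a butanoyl or a benzoyl group on the same nitrogen would test. A methyl group on the amide nitrogen would show whether the amide hydrogen is needed, and a methylsulfonyl group in place of acetyl whether the carbonyl is.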